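The compounds below may be only part of what the source reports. "The series", "measured", "known", "first", "only" and "open" are said of these compounds alone.

Working notes on the series. Among the compounds with values here, compound 1 `COc1ccc(-c2nnc(SCc3cccc(Cl)c3)o2)c(O)c1` and compound 2 `COc1ccc(-c2nnc(SCc3ccccc3F)o2)c(O)c1` are the two measured members in an in vitro assay on Sf21 cells for inhibition of phosphatidylinositol 4,5-bisphosphate 3-kinase catalytic subunit beta isoform (Homo sapiens); a lower number here means a stronger inhibitor, a higher number a weaker inhibitor. Compound 1 gives 43700 nM and compound 2 gives 51800 nM; the step of a 1.2-fold higher number from compound 1 to compound 2 (0.07 log units; within the scatter) leaves the two side by side within the scatter, so neither number is set apart from the other. Compound 3 `COc1ccc(-c2nnc(SCc3cccc([N+](=O)[O-])c3)o2)c(O)c1` is not yet measured. It differs from compound 1 by nitro in place of chloro on an aromatic carbon. Within the data shown here, no measured step swaps chloro for nitro, and the only step on hand, from compound 1 to compound 2, did not move the number beyond the scatter. For compound 3 the estimate is a 1.0-fold higher number from compound 1 to compound 3 (0.01 log units; within the scatter) in this assay, giving an expected 45000 nM with a range from 18000 nM to 110000 nM.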

Compound 3, half-maximal inhibitory concentration: > 100000 nM
Compound 3: no number, only a limit (the forecaster's own chance of this, stated with the estimate: 15%); middle value at least 2.2-fold (0.34 log units) from the limit.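

Nitro in place of chloro gives an at least 2.2-fold higher number from compound 1 to compound 3 (0.35 log units; beyond the scatter) in this assay, the first step in the series beyond the scatter, so this aromatic carbon does not tolerate every replacement. Compound 3 carries only a limit and not a number, so the full size of the step cannot be read: the limit of > 100000 nM in this assay, at which 1 of the 3 values shown sits.

The compounds shown leave open how an amine or a nitrile at this same place would read. They also leave open whether any change to the shared core gives a stronger inhibitor than compound 1 and compound 2.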